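Swapping sec-butyl for 2-hydroxyethyl in compound 4

A few compounds are considered here, and "the series" means these few. Any claim that something is new, unique, unknown or untested is made for them only; others in the source may bear on it.

Measured so far in a functional assay on Caco-2 cells (Homo sapiens) for antiproliferative activity, read by MTT assay, with a stated time of 48 h; a lower number here means a stronger inhibitor, a higher number a weaker inhibitor:
Compound 1 `C#CC(C)OC(=O)c1ccc(C(CC)(CC)c2ccc(OCCC(O)(CC)CC)c(C)c2)n1CC`: > 50000 nM (a limit)
Compound 2 `CCOC(=O)C(CC(=O)OC)NC(=O)c1ccc(C(CC)(CC)c2ccc(OCCC(O)(CC)CC)c(C)c2)n1CC`: 3020 nM
Compound 3 `CCC(C)C(CO)NC(=O)c1ccc(C(CC)(CC)c2ccc(OCCC(O)(CC)CC)c(C)c2)n1CC`: > 50000 nM (a limit)

Compound 3 gives > 50000 nM as its result, which is a limit and not a number. This puts it on (the limit of > 50000 nM in this assay, at which 2 of the 3 values shown sit).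

The next structure, compound 4 `CCn1c(C(=O)NC(CO)CCO)ccc1C(CC)(CC)c1ccc(OCCC(O)(CC)CC)c(C)c1`, differs from compound 3 in one place: 2-hydroxyethyl in place of sec-butyl on a saturated chain carbon bound to an amide-type nitrogen and a saturated chain carbon. In words, 2-hydroxyethyl stands in place of sec-butyl on a saturated chain carbon bound to an amide-type nitrogen and a saturated chain carbon.

Within the data shown here, no measured step makes this exact swap. The closest evidence is a change on an amide-type nitrogen, an at least 16-fold higher number from compound 2 to compound 3 (1.21 log units; beyond the scatter), which shows that the group there can matter a great deal. The step of an at least 16-fold lower number from compound 1 to compound 2 (1.21 log units; beyond the scatter) is also large, while a step that the two limits leave unreadable from compound 1 to compound 3 cannot be read.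

Compound 4 does not carry the group found in compound 2, so only a modest move towards a lower number is expected, and another limit is quite possible. The expected step, an estimate only, is an at least 1.2-fold lower number from compound 3 to compound 4 (0.09 log units; that floor lies within the scatter). For compound 4 the estimated value is 40000 nM, with an expected range from 8000 nM to 100000 nM.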

Compound 4, half-maximal inhibitory concentration: 40200 nM
The estimate for compound 4 lay 1.0-fold (0.00 log units) below the measured number, and the stated range covers the measured number.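

With 2-hydroxyethyl in place of sec-butyl, compound 4 gives a measured number in this assay, 40200 nM. Compound 3 and compound 1 each have only a limit, not a number: the limit of > 50000 nM in this assay, at which 2 of the 4 values shown sit.

The change at this saturated chain carbon can therefore be read only as a floor, an at least 1.2-fold lower number from compound 3 to compound 4 (0.09 log units; that floor lies within the scatter), and the same holds for the change on the carbonyl carbon, an at least 1.2-fold lower number from compound 1 to compound 4 (0.09 log units; that floor lies within the scatter), while the comparison on the amide-type nitrogen shows that this new group still leaves a wide gap, a 13-fold higher number from compound 2 to compound 4 (1.12 log units; beyond the scatter).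

From the compounds shown here alone, the true size of the swap stays unknown, and these compounds cannot separate any effect of the hydroxyl of 2-hydroxyethyl from that of losing sec-butyl. Going by these compounds, it also remains open whether an amine or a carboxylic acid in place of that hydroxyl, or a longer chain carrying it, would bring the number closer to that of compound 2.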